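Ester replacement on the benzylic aryl of compound 2

The compounds below may be only part of what the source reports. "The series", "measured", "known", "first", "only" and "open" are said of these compounds alone.

Measured so far:
compound 1 `Cc1cc(C(=O)O)ccc1CN1C(C)CC[C@H](O[C@H](CO)c2cc(Cl)cc(Cl)c2)[C@@H]1c1ccccc1` gives 36000 nM in an assay on isolated protein for activation of cGMP-dependent protein kinase 1 (Homo sapiens), read by ADP-Glo, with stated times of 30 min and 2 h, in the presence of a further agent that is not named here; on this read-out lower numbers stand for an effect already at smaller amounts and higher numbers for an effect only at larger amounts of compound
compound 2 `O=C(O)c1ccc(CN2CCC[C@H](O[C@H](CO)c3cc(Cl)cc(Cl)c3)[C@@H]2c2ccccc2)c([N+](=O)[O-])c1` gives 520 nM in this assay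
compound 3 `Cc1cc(C(=O)O)ccc1CN1CC[C@H](OC(CO)c2cc(Cl)cc(Cl)c2)[C@@H]1c1ccccc1` gives 133000 nM in this assay

Of the three measured compounds, compound 2 has the lowest number in this assay; compound 1 lies nearest to it and compound 3 furthest, both beyond the scatter. Going by the values given here, the aryl group on the saturated chain carbon bound to the amine nitrogen in the ring differs across all three, and the two compounds with the weaker numbers, compound 1 and compound 3, also differ from compound 2 in the ring that holds that nitrogen, so no single step between measured compounds is available.

Compound 4 `COC(=O)c1ccc(CN2CCC[C@H](O[C@H](CO)c3cc(Cl)cc(Cl)c3)[C@@H]2c2ccccc2)c(C)c1` is not yet measured. It differs from compound 2 in one place: a group of 11 heavy atoms (9 carbon, 2 oxygen; one six-membered aromatic ring of carbon only) in place of a group of 12 heavy atoms (7 carbon, 1 nitrogen, 4 oxygen; one six-membered aromatic ring of carbon only), on a saturated chain carbon bound to an amine nitrogen in a ring. The 4-carboxy-2-nitrophenyl group leaves, and a group with no common name enters.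

Among the compounds with values here, every measured compound carries a carboxylic acid on this aryl ring; no measured compound shows what its absence does. A step from compound 2 to compound 4 toward higher numbers, beyond the scatter, is expected in this assay, because compound 2 gives 520 nM as the strongest number of the set with the acid in place, while the other acids give weaker numbers still. For compound 4 a value of 40000 nM is estimated, within 6000 nM to 250000 nM, meaning an expected step of a 77-fold higher number from compound 2 to compound 4 (1.89 log units; beyond the scatter).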

Compound 4, half-maximal effective concentration: 900 nM
Beside the measured number, compound 4's estimate is 44-fold (1.65 log units) above it; measured number outside the range, below it.
By their numbers in this assay, from the lowest: compounds 2 and 4 (each within the scatter of the next); then compound 1; then compound 3.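

In this assay, the step of a 1.7-fold higher number from compound 2 to compound 4 (0.24 log units; within the scatter) shows that, for this pair, the 4-carboxy-2-nitrophenyl group on the saturated chain carbon bound to the amine nitrogen in the ring can be replaced by a group without a carboxylic acid while the number stays within the scatter. The entering group carries a methyl ester and a methyl group, the leaving group a carboxylic acid and a nitro group, so two features change together and the step cannot be assigned to either one alone. No measurement given here explains why the two numbers stay within the scatter of each other.

Open, on these data alone, is how each feature acts separately: a ring with the carboxylic acid and a methyl group, or one with the methyl ester and a nitro group, would separate the two changes. Also open, as far as these compounds go, is what a primary amide or a nitrile would give in place of the methyl ester, and steps from compound 1 and compound 3 to compound 4 cannot be read, as each differs from it in more than one place.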